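Adding a Hydroxy Group to a Phenethyl Side Chain

This account rests on a few compounds, and the source may have more. Where it says the series, first, only, none or still open, it means among the compounds named here.

Compound 1 `COC(=O)c1c(CCc2ccccc2)cc2c(c1O)CC(O)C(C)(C)O2`: > 40000 nM, a limit
Compound 2 `O=C1C=Cc2c(O)cc(CCc3ccccc3O)cc2OC1`: 13800 nM
Compound 3 `CC1=CCc2c(O)cc(CCc3ccccc3)cc2OC1`: > 40000 nM, a limit

In a functional assay on SW-620 cells (Homo sapiens) for cytotoxicity, read by MTT assay, with a stated time of 48 h (on this read-out lower numbers stand for stronger inhibition and higher numbers for weaker inhibition), compound 3 gives only a limit, > 40000 nM, so its true value is not known. Compound 1 likewise stops at a limit in this assay. Going by the values given here, compound 2 is the one measured number, and it carries 2-hydroxyphenyl on a different core, so it does not connect to compound 3 by a single change. Much of the picture is the limit of > 40000 nM in this assay, at which 2 of the 3 values shown sit.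

Compound 4 `CC1=CCc2c(O)cc(CCc3ccccc3O)cc2OC1` differs from compound 3 by hydroxy in place of hydrogen on an aromatic carbon. With compound 3 at a limit, the size of this step cannot be read from the data. A modest gain in this assay, roughly toward compound 2 at 13800 nM, is expected, though a result beyond the scatter is far from certain. Compound 4 is therefore estimated near 25000 nM, between 8000 nM and 60000 nM. That estimate implies an expected step of an at least 1.6-fold lower number from compound 3 to compound 4 (0.20 log units; that floor lies within the scatter).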

Compound 4, half-maximal inhibitory concentration: > 40000 nM
Compound 4: a limit, no number; the forecaster's own chance of this, stated with the estimate: 45%; middle value at least 1.6-fold (0.20 log units) from the limit.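

Compound 3 and compound 4 both stop at a limit in this assay, so no step can be read between them. From the compounds shown here alone, whether hydroxy in place of hydrogen changes the read-out on this core at all stays open.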